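This account rests on a few compounds, and the source may have more. Where it says the series, first, only, none or still open, it means among the compounds named here.

Measured so far in an assay on CHO cells for displacement of a labelled ligand from 5-hydroxytryptamine receptor 7 (Homo sapiens); on this read-out lower numbers stand for stronger inhibition and higher numbers for weaker inhibition:

- compound 1 `CCC1(CCCCN2CCN(c3ccccc3)CC2)C(=O)Nc2ccccc21`: 2.07 nM
- compound 2 `CCC1(CCCCN2CCN(c3ccccc3OC)CC2)C(=O)Nc2ccccc21`: 5.38 nM
- compound 3 `CCC1(CCCCN2CCN(c3cccc(OC)c3)CC2)C(=O)Nc2ccccc21`: 2.55 nM

Compound 3 sits within the scatter of compound 1; the two numbers cannot be told apart. Against compound 2 it is clearly set off, the step being a 2.1-fold lower number from compound 2 to compound 3 (0.32 log units; beyond the scatter). The same ring thus carries a methoxy group in three different ways, and only one of them moves the number beyond the scatter: a 2.6-fold higher number from compound 1 to compound 2 (0.41 log units; beyond the scatter), while a 1.2-fold higher number from compound 1 to compound 3 (0.09 log units; within the scatter).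

Compound 4 `CCC1(CCCCN2CCN(c3ccc(OC)cc3)CC2)C(=O)Nc2ccccc21` has not been measured. It differs from compound 3 only in this: 4-methoxyphenyl in place of 3-methoxyphenyl on an amine nitrogen in a ring. Going by the values given here, none of the measured steps covers this exact change. Among the compounds with values here, the steps that bear on it are those in which the methoxy group changes or gains a position on the same aromatic ring: one modest, one within the scatter. From them the step expected for compound 4 in this assay is small, most likely a 1.4-fold higher number from compound 3 to compound 4 (0.14 log units; within the scatter), with no strong reason to lean either way. Compound 4 is therefore estimated at 3.5 nM, within a range of 1.5 nM to 9 nM.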

Compound 4, inhibition constant: 25.4 nM
For compound 4 the middle estimate is 7.3-fold (0.86 log units) below the measured one; the measured number lies above the stated range.
By their numbers in this assay, from the lowest: compounds 1 and 3 (each within the scatter of the next); then compound 2; then compound 4.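

In this assay, going by these compounds alone, where the methoxy group sits on the phenyl ring proves to matter far more than the earlier compounds showed: 4-methoxyphenyl in place of 3-methoxyphenyl gives a 10-fold higher number from compound 3 to compound 4 (1.00 log units; beyond the scatter), although the two groups have the same atoms. The 4-methoxyphenyl group also does worse than the 2-methoxyphenyl group, the only placement that had earlier moved the number beyond the scatter, with a 4.7-fold higher number from compound 2 to compound 4 (0.67 log units; beyond the scatter), and relative to the unsubstituted phenyl ring the change is a 12-fold higher number from compound 1 to compound 4 (1.09 log units; beyond the scatter). Nothing among the data given accounts for this difference between the placements.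

The compounds shown leave open whether this penalty belongs to the methoxy group alone or would also appear with a hydroxy group or a chlorine atom on the same ring. They also leave open whether it would persist with a longer chain in place of the ethyl group on the shared core.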